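Thiosemicarbazone series: aryl swap at the imine carbon

A few compounds are considered here, and "the series" means these few. Any claim that something is new, unique, unknown or untested is made for them only; others in the source may bear on it.

Measured so far:
compound 1, `COc1ccc(/C=N/NC(=S)NC(C)(C)[C@H]2CC=C(C)CC2)cc1`, 13300 nM
compound 2, `CC1=CC[C@H](C(C)(C)NC(=S)N/N=C/c2ccccc2Cl)CC1`, 19300 nM
compound 3, `CC1=CC[C@H](C(C)(C)NC(=S)N/N=C/c2ccccc2[N+](=O)[O-])CC1`, 10600 nM

All three numbers come from a functional assay on UACC-62 cells (Homo sapiens) for inhibition, read by sulforhodamine B assay, with a stated time of 48 h; on this read-out higher numbers stand for weaker inhibition of growth and lower numbers for stronger inhibition of growth. Compound 2 cannot be separated from the other two on these numbers: the step of a 1.5-fold higher number from compound 1 to compound 2 (0.16 log units; within the scatter) and the step of a 1.8-fold lower number from compound 2 to compound 3 (0.26 log units; within the scatter) both fall inside the usual scatter, so the three compounds stand as one group on this read-out, and compound 2 is simply the one from which the next step is taken.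

Compound 4, `CC1=CC[C@H](C(C)(C)NC(=S)N/N=C/c2cccs2)CC1`, differs from compound 2 in one place: thiophen-2-yl in place of 2-chlorophenyl on a carbon with a double bond to nitrogen. Among the measured compounds shown here, the two measured steps are the only guide, and both concern the same position on the shared core. Each exchanges one aromatic substituent for another there, and each stays within the scatter. Nothing in the series therefore points to a step beyond the scatter in this assay for this further exchange, in either direction.

The expectation for compound 4 is a number near that of compound 2, with the step of a 1.3-fold lower number from compound 2 to compound 4 (0.11 log units; within the scatter) estimated as within the scatter. The estimated value for compound 4 is 15000 nM, with a range from 5000 nM to 45000 nM.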

Compound 4, concentration for 50% growth inhibition: 2600 nM
Estimate against measurement, compound 4: 5.8-fold (0.76 log units) above; the whole stated range lies above it.
By their numbers in this assay, from the lowest: compound 4; then compounds 3, 1 and 2 (each within the scatter of the next).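

At the carbon with a double bond to nitrogen, the aryl group can move the number in this assay beyond the scatter: thiophen-2-yl in place of 2-chlorophenyl gives a 7.4-fold lower number from compound 2 to compound 4 (0.87 log units; beyond the scatter) and thiophen-2-yl in place of 4-methoxyphenyl gives a 5.1-fold lower number from compound 1 to compound 4 (0.71 log units; beyond the scatter) as well. The steps among the three phenyl compounds had shown no such separation, so this position is not flat across aromatic groups; against compound 3 only the printed values stand, with compound 3 at 10600 nM and compound 4 at 2600 nM in the same assay. No measurement shown here accounts for the difference.

The compounds shown leave open whether the lower number goes with the five-membered aromatic ring as such or with its sulfur, a question that furan-2-yl or pyrrol-2-yl at the same carbon would address. Also open, on these data alone, is where an unsubstituted phenyl or a pyridin-2-yl group would fall relative to thiophen-2-yl on the shared core, and whether a methyl group on the thiophene ring would keep the number of compound 4.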